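Cytotoxicity notes on a triazole-sulfonamide series

The source may hold more compounds than are shown below. What is called first, only, known or untested is meant among the compounds shown, and "the series" means these compounds.

The series shares a core carrying a sulfonamide-linked aromatic ring and a triazole bearing an aryl group on an aromatic nitrogen. Compound 1 `Cc1cccc(-n2cc(-c3ccccc3NS(=O)(=O)c3c[nH]c(=O)[nH]c3=O)nn2)c1` is the point of comparison for the two-ring arrangement; in an ADME assay on L02 cells (Homo sapiens) for cytotoxicity, read by MTT assay, with a stated time of 24 h (on this read-out lower numbers stand for higher toxicity in this test and higher numbers for lower toxicity in this test), compound 1 gives 21900 nM. Compound 2 `O=c1[nH]cc(S(=O)(=O)Nc2ccccc2-c2cn(-c3cccc(F)c3)nn2)c(=O)[nH]1` has been reported in this assay only with the word "not toxic" (no number reported), and no number accompanies it. Compound 3 `Cc1cccc(-n2cc(-c3cccc(NS(=O)(=O)c4c[nH]c(=O)[nH]c4=O)c3)nn2)c1` is the direct parent of the new entry; in this assay compound 3 gives 28300 nM. On the two numbers available, compound 3 stands at the upper end, but its distance to compound 1 is within the usual scatter, so the two cannot be told apart.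

Compound 4 `O=c1[nH]cc(S(=O)(=O)Nc2cccc(-c3cn(-c4ccccc4Cl)nn3)c2)c(=O)[nH]1` differs from compound 3 in one place: 2-chlorophenyl in place of 3-methylphenyl on an aromatic nitrogen. For the measured compounds named here, no step between measured compounds exists for this kind of change, and the two numbers in hand sit close together, so no step beyond the scatter is expected in either direction. For compound 4 the estimate in this assay is 25000 nM, with a range from 10000 nM to 65000 nM, meaning an expected step of a 1.1-fold lower number from compound 3 to compound 4 (0.05 log units; within the scatter).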

Compound 4, half-maximal cytotoxic concentration: 11500 nM
Compound 4: the middle estimate sits 2.2-fold (0.34 log units) above what was measured; the measured number falls inside the stated range.
By their numbers in this assay, from the lowest: compounds 4, 1 and 3 (each within the scatter of the next, the first and the last beyond it).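

In this assay, for the compounds shown here, the aryl group on the aromatic nitrogen gives the first single-place change with a readable step: a 2.5-fold lower number from compound 3 to compound 4 (0.39 log units; beyond the scatter). The position is therefore not silent on this read-out, and the modest step points towards higher toxicity in this test, even though the leaving and entering groups both hold 7 heavy atoms, a single six-membered carbon ring and no hydrogen-bond donors or acceptors. Nothing at hand accounts for the step, which rests on one pair of compounds.

The step swaps the substituent and its place on the phenyl ring in a single move, so the pair cannot show whether the lower number goes with chlorine in place of methyl or with the 2-substituted ring in place of the 3-substituted one; a 3-chlorophenyl or 2-methylphenyl group on the same nitrogen would separate the two. Going by these compounds, it also remains open how this position would respond to a group of another kind, such as a pyridyl ring, a carboxylic acid or an amine on the phenyl ring.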